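A few compounds are considered here, and "the series" means these few. Any claim that something is new, unique, unknown or untested is made for them only; others in the source may bear on it.

Compound 1 `CC(C(=O)NCc1ccc(C(F)(F)F)nc1NC1CCCCC1)c1ccc(NS(C)(=O)=O)c(F)c1` was tested in a functional assay on CHO-K1 cells for antagonist activity at transient receptor potential cation channel subfamily V member 1 (Homo sapiens), read by FLIPR (on this read-out higher numbers stand for weaker inhibition and lower numbers for stronger inhibition), where compound 1 gives 20.4 nM, the lowest of the two numbers recorded. Compound 2 `CC(C(=O)NCc1ccc(C(F)(F)F)nc1NCc1ccc(Cl)cc1)c1ccc(NS(C)(=O)=O)c(F)c1` gives 65.7 nM, and the step of a 3.2-fold higher number from compound 1 to compound 2 (0.51 log units; beyond the scatter) lies beyond the scatter. Compound 3 `CC(C(=O)NCc1ccc(C(F)(F)F)nc1NCc1cccnc1)c1ccc(NS(C)(=O)=O)c(F)c1` is reported as "not active" (no number reported), with no number given. Compound 4 `CC(C(=O)NCc1ccc(C(F)(F)F)nc1N(C)C)c1ccc(NS(C)(=O)=O)c(F)c1` has not yet been measured; it differs from compound 1 in one place: dimethylamino in place of cyclohexylamino on an aromatic carbon. Going by the values given here, the one step that bears on this change is the step from compound 1 to compound 2, where a different group on the nitrogen on the aromatic ring gave weaker inhibition, and compound 3, with yet another group there, lost activity altogether. A weaker number is therefore expected for compound 4, a step of about a 7.4-fold higher number from compound 1 to compound 4 (0.87 log units; beyond the scatter), giving an estimate of 150 nM with a range from 40 nM to 800 nM.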

Compound 4, inhibition constant: 19.1 nM
Compound 4: the middle estimate sits 7.9-fold (0.90 log units) above what was measured; the measured number lies below the stated range.
By their numbers in this assay, from the lowest: compounds 4 and 1 (each within the scatter of the next); then compound 2.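

In this assay the step of a 1.1-fold lower number from compound 1 to compound 4 (0.03 log units; within the scatter) shows that this position does not depend on the cyclohexyl ring or on a hydrogen-bond donor on the nitrogen, at least in this pair. The step of a 3.4-fold lower number from compound 2 to compound 4 (0.54 log units; beyond the scatter) shows that dimethylamino also gives stronger inhibition than (4-chlorobenzyl)amino here. No available evidence explains these differences. Still open, from the compounds shown here alone, is how a plain amino group, methylamino or morpholine would behave at this position, and whether any of them would give stronger inhibition than dimethylamino.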